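Swapping a Fluorine for Chlorine in a Receptor Binder

The compounds below may be only part of what the source reports. "The series", "measured", "known", "first", "only" and "open" are said of these compounds alone.

Of the compounds shown here, three have been measured in an assay on CHO cells for displacement of a labelled ligand from prostaglandin D2 receptor 2 (Homo sapiens), read by scintillation counting; a lower number here means a stronger inhibitor, a higher number a weaker inhibitor. Compound 1, with the structure `CCCS(=O)(=O)c1cccc(C#Cc2cc(F)ccc2OCC(=O)O)c1`, gives 65 nM in this assay. Compound 2, with the structure `CCCS(=O)(=O)c1cccc(C#Cc2c(OCC(=O)O)cccc2-c2ccsc2)c1`, gives 18 nM in this assay. Compound 3, with the structure `COC1c2ccc(C#Cc3cc(Cl)ccc3OCC(=O)O)cc2S(=O)(=O)C1(C)C`, gives 21 nM in this assay. On these three numbers compound 1 stands with the highest value, and both of the other two compounds lie beyond the usual scatter below it, so compound 1 is the weakest binder of the three.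

The step of interest leads from compound 1 to compound 4, whose structure is `CCCS(=O)(=O)c1cccc(C#Cc2cc(Cl)ccc2OCC(=O)O)c1` and which has not yet been measured. The two differ in one place: chloro in place of fluoro on an aromatic carbon. Going by the values given here, no pair of measured compounds shows this exact change on its own, so its size cannot be read directly from the data. Compound 3 also carries a chloro group on the same kind of position and gives 21 nM, but it differs from compound 1 in more than one place, so that comparison is only a loose hint.

The expected step from compound 1 to compound 4 is a 1.6-fold lower number from compound 1 to compound 4 (0.21 log units; within the scatter), most likely small and within or close to the scatter, leaning toward a lower number. The expected value of compound 4 in this assay is therefore 40 nM, with a range from 15 nM to 110 nM.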

Compound 4, inhibition constant: 9 nM
The estimate for compound 4 lay 4.4-fold (0.65 log units) above the measured number, and the stated range ends above it.
By their numbers in this assay, from the lowest: compounds 4, 2 and 3 (each within the scatter of the next, the first and the last beyond it); then compound 1.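

In this assay, replacing fluoro with chloro on the aromatic carbon para to the carboxymethoxy group gives a 7.2-fold lower number from compound 1 to compound 4 (0.86 log units; beyond the scatter), a step beyond the usual scatter. Going by these compounds alone, this pair isolates the change for the first time, and it shows that this position is sensitive to which of these two halogens it carries. The sensitivity appears even though each group counts as one heavy atom, neither adds a hydrogen-bond donor or acceptor, and neither carries a net charge, but no measurement shown here explains why the number falls.

This is still one step on one core, so it does not establish a general rule for this position or show whether the same exchange would have a similar effect on another core, such as that of compound 3. As far as these compounds go, it also remains open how the position would respond to a bromo, methyl, trifluoromethyl or nitrile group, or to a plain hydrogen, and those comparisons would show whether chloro is a special case or part of a wider trend.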